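The source may hold more compounds than are shown below. What is called first, only, known or untested is meant among the compounds shown, and "the series" means these compounds.

Measured compounds:
- compound 1, `ClCc1ccccc1Cn1cnc2c(Cl)nc(Cl)nc21`, in a functional assay on OVCAR-4 cells (Homo sapiens) for cytotoxicity, read by sulforhodamine B assay, with a stated time of 48 h; on this read-out higher numbers stand for weaker inhibition of growth and lower numbers for stronger inhibition of growth: 1770 nM
- compound 2, `ClCc1ccccc1Cn1cnc2c(Cl)ncnc21`, in this assay: 3380 nM
- compound 3, `ClCc1cccc(Cn2cnc3c(Cl)ncnc32)c1`, in this assay: 2340 nM

All three share one core and differ in the substitution of the core or in where the side chain is attached. Among the compounds with values here, the one change that is measured on its own is the step from compound 2 to compound 1, (chloro in place of hydrogen on an aromatic carbon). This gives a 1.9-fold lower number from compound 2 to compound 1 (0.28 log units; within the scatter). Compound 3 is built from the same atoms as compound 2 but joined differently; the difference between the two cores is not broken down here. The values of compound 3 and compound 2 lie within the usual scatter of each other, and so do those of compound 3 and compound 1, so nothing can be read from their order.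

Compound 4, `ClCc1cccc(Cn2cnc3c(Cl)nc(Cl)nc32)c1`, has not been measured. Within the data shown here, it differs from compound 3 by chloro in place of hydrogen on an aromatic carbon, the same change, at the same place, as the one from compound 2 to compound 1. Among the measured compounds shown here, the expectation for compound 4 therefore rests on the step from compound 2 to compound 1 because a 1.9-fold lower number from compound 2 to compound 1 (0.28 log units; within the scatter) is the only measurement of this change. On that basis compound 4 is expected to show a 1.8-fold lower number from compound 3 to compound 4 (0.26 log units; within the scatter), a step that, like its model, would fall within the scatter. The estimate for compound 4 in this assay is 1300 nM, with a likely range from 600 nM to 2800 nM.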

Compound 4, concentration for 50% growth inhibition: 5490 nM
For compound 4 the middle estimate is 4.2-fold (0.63 log units) below the measured one, outside the stated range (above it).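

In this assay, chloro in place of hydrogen on an aromatic carbon, between two ring nitrogen atoms, gives a 2.3-fold higher number from compound 3 to compound 4 (0.37 log units; beyond the scatter), a step beyond the scatter, though a modest one. Set beside the earlier measurement of the same change, this step shows that the result on one core does not carry over to the other: the same change on two cores in this assay, a 1.9-fold lower number (0.28 log units; within the scatter) from compound 2 to compound 1 and a 2.3-fold higher number (0.37 log units; beyond the scatter) from compound 3 to compound 4, 4.5-fold (0.65 log units) apart, beyond the scatter of two such steps The change therefore cannot be treated as a fixed increment across these two cores, but the comparison rests on one pair of compounds per core, in one cell line, and does not show which difference between the cores is responsible or how any further core would respond.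

The compounds shown leave open how an amine or a methoxy group in place of that hydrogen would behave on either core, and whether such a group would also give steps that differ between the two. Also open, going by these compounds, is whether the difference between the steps persists when the chloro on the side chain gives way to a hydroxyl group, or when that side chain is replaced by a longer chain.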